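The compounds below may be only part of what the source reports. "The series", "measured", "known", "first", "only" and "open" are said of these compounds alone.

Compound 1 `Cc1cc(NC(=O)Cn2nnc(-c3ccccc3)n2)n(C2CCCCC2)n1` is the reference point of this small series. In an assay on HEK293 cells for activation of Kir3.1/Kir3.2 (Homo sapiens), read by thallium flux (on this read-out higher numbers stand for an effect only at larger amounts of compound and lower numbers for an effect already at smaller amounts), compound 1 gives 96 nM, the lowest number among the three measured compounds. Compound 2 `Cc1cc(NC(=O)Cn2nnc(-c3ccccc3)n2)n(C2CCS(=O)(=O)C2)n1` carries 1,1-dioxothiolan-3-yl in place of cyclohexyl on the aromatic nitrogen, and in this assay compound 2 gives 1030 nM; the change is an 11-fold higher number from compound 1 to compound 2 (1.03 log units; beyond the scatter). Compound 3 `CC1CC1c1cc(NC(=O)Cn2nnc(-c3ccccc3)n2)n(C2CCCCC2)n1` carries 2-methylcyclopropyl in place of methyl on an aromatic carbon, and in this assay compound 3 gives 843 nM; the change is an 8.8-fold higher number from compound 1 to compound 3 (0.94 log units; beyond the scatter). Both measured steps move away from compound 1 by a clear margin, and both touch the pyrazole end of the molecule.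

Compound 4 `Cc1cc(NC(=O)Cn2nnc(-c3cccnc3)n2)n(C2CCCCC2)n1` changes a different end: pyridin-3-yl in place of phenyl on an aromatic carbon. Going by the values given here, no measured step touches the phenyl on the tetrazole, so the two known steps give only a general sense of how sensitive this series is to change, not a direct guide. The swap keeps the ring size and shape and adds one hydrogen-bond acceptor, which is often tolerated. For compound 4 in this assay the expected step is a 2.3-fold higher number from compound 1 to compound 4 (0.36 log units; beyond the scatter), a mild loss of potency. The estimated value for compound 4 is 220 nM, with a likely range from 70 nM to 700 nM.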

Compound 4, half-maximal effective concentration: 1930 nM
For compound 4 the middle estimate is 8.8-fold (0.94 log units) below the measured one, and the stated range ends below it.
By their numbers in this assay, from the lowest: compound 1; then compounds 3, 2 and 4 (each within the scatter of the next, the first and the last beyond it).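

Exchanging phenyl for pyridin-3-yl brings a 20-fold higher number from compound 1 to compound 4 (1.30 log units; beyond the scatter) in this assay, even though the new group has the same count of heavy atoms and remains a six-membered aromatic ring. The printed differences are a ring carbon replaced by nitrogen and the hydrogen-bond acceptor counted with it, so a seemingly small edit at this place, on an aromatic carbon of a five-membered aromatic ring with 4 nitrogen, is enough to produce a large step. Together with the earlier steps, this means that all three changes shown from compound 1 raise the number beyond the scatter, with none going against that, and the sensitivity is no longer confined to the other end of the molecule; nothing here gives a measured explanation for the loss.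

The compounds shown leave open whether the step depends on the ring nitrogen as such or on where it sits in the ring, a question that pyridin-2-yl or pyridin-4-yl at this place could address. They also leave open whether a phenyl carrying a fluorine or a methoxy group would keep, lower or raise the number seen for compound 1.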